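Cytotoxicity of amino-acid ester prodrugs in the series

The source may report more compounds than this note shows. Statements on the series, on what has been measured and on what is new or still open speak of the compounds shown alone.

Compound 1 `CCCCCc1ccc(-c2cc3cn([C@H]4C[C@H](O)[C@@H](COC(=O)[C@@H](NC(=O)[C@@H]5CCCN5C(=O)[C@@H](N)C(C)C)C(C)C)O4)c(=O)nc3o2)cc1`: > 100000 nM in an ADME assay on HEL cells (Homo sapiens) for inhibition; a higher number here means that more compound is tolerated, a lower number that less compound is tolerated
Compound 2 `CCCCCc1ccc(-c2cc3cn([C@H]4C[C@H](OC(=O)[C@@H](NC(=O)[C@@H]5CCCN5C(=O)[C@@H](N)C(C)C)C(C)C)[C@@H](COC(=O)[C@@H](NC(=O)[C@@H]5CCCN5C(=O)[C@@H](N)C(C)C)C(C)C)O4)c(=O)nc3o2)cc1`: 50000 nM in this assay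
Compound 3 `CCCCCc1ccc(-c2cc3cn([C@H]4C[C@H](OC(=O)[C@@H](NC(=O)[C@@H]5CCCN5C(=O)[C@@H](N)C(C)C)C(C)C)[C@@H](CO)O4)c(=O)nc3o2)cc1`: 17000 nM in this assay

Compound 1 stands at the ceiling of what this assay reports: its value is a limit, not a number, (the limit of > 100000 nM in this assay, at which 1 of the 3 values shown sits). It is the only one of the three at that limit. Compound 2 and compound 3, which carry the ester group on a different part of the shared core, each give a number; the value of compound 3 is the lower of the two. For the measured compounds named here, no pair of these three differs in a single place, so no single measured step exists.

Compound 4 `CCCCCc1ccc(-c2cc3cn([C@H]4C[C@H](O)[C@@H](COC(=O)[C@H](CC(C)C)NC(=O)[C@@H]5CCCN5C(=O)[C@@H](N)C(C)C)O4)c(=O)nc3o2)cc1` differs from compound 1 in one place only: isobutyl in place of isopropyl on a saturated chain carbon bound to an amide-type nitrogen and a carbonyl carbon. Going by the values given here, no measured step of this kind exists in the set. The step from compound 1 to compound 4 in this assay is expected to be none beyond the scatter, so compound 4 is expected to reach the limit again, or to sit close to it, with the step of a number no higher from compound 1 to compound 4 (the limit leaves the size open) as the working estimate. Compound 4 is expected to give about 100000 nM, with a range from 40000 nM to 250000 nM.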

Compound 4, half-maximal cytotoxic concentration: 31000 nM
The estimate for compound 4 lay 3.2-fold (0.51 log units) above the measured number; measured number outside the range, below it.
By their numbers in this assay, from the lowest: compounds 3, 4 and 2 (each within the scatter of the next, the first and the last beyond it). At a limit, above all of these: compound 1.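

In this assay, the group on the saturated chain carbon bound to an amide-type nitrogen and a carbonyl carbon is not silent: isobutyl in place of isopropyl gives an at least 3.2-fold lower number from compound 1 to compound 4 (0.50 log units; beyond the scatter). For the compounds shown here, compound 1 holds a limit and not a number, so the full size of this step stays open: the limit of > 100000 nM in this assay, at which 1 of the 4 values shown sits. This is the only single-place step, and a change confined to this chain is enough to bring compound 4 off the limit to a measured number.

As far as these compounds go, a single pair gives no trend, so it remains open whether a longer chain, a benzyl group or a chain ending in an amine at this place would follow the same direction. From the compounds shown here alone, it also remains open whether isobutyl in place of isopropyl acts the same way when the ester sits as in compound 2 or compound 3.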